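A few compounds are considered here, and "the series" means these few. Any claim that something is new, unique, unknown or untested is made for them only; others in the source may bear on it.

Three compounds share one core and differ only in what sits on one aromatic carbon of the fused ring. Compound 1 `c1ccc(Oc2ccc(Cc3nc4ccccc4[nH]3)cc2)cc1` carries a hydrogen there and in an assay on membranes from brain for binding affinity to Adrenergic receptor alpha-1 (Rattus norvegicus) (a higher number here means a weaker inhibitor, a lower number a stronger inhibitor), gives 4200 nM. Compound 2 `CCCS(=O)(=O)Nc1ccc2[nH]c(Cc3ccc(Oc4ccccc4)cc3)nc2c1` carries a (propylsulfonyl)amino group and gives 4800 nM; the change from compound 1 to compound 2 is a 1.1-fold higher number from compound 1 to compound 2 (0.06 log units; within the scatter). Compound 3 `O=S(=O)(Nc1ccc2[nH]c(Cc3ccc(Oc4ccccc4)cc3)nc2c1)c1ccccc1` carries a (phenylsulfonyl)amino group and gives 14000 nM, the highest of the three numbers: it lies a 3.3-fold higher number from compound 1 to compound 3 (0.52 log units; beyond the scatter) and a 2.9-fold higher number from compound 2 to compound 3 (0.46 log units; beyond the scatter).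

Compound 4 `CN(c1ccc2[nH]c(Cc3ccc(Oc4ccccc4)cc3)nc2c1)S(C)(=O)=O` is not yet measured. It differs from compound 3 in that (methyl(methylsulfonyl)amino in place of (phenylsulfonyl)amino on an aromatic carbon). Two of the measured steps bear on this. The step from compound 2 to compound 3 shows that swapping propyl for phenyl on the sulfonyl sulfur raised the number modestly, and the step from compound 1 to compound 2 shows that a (propylsulfonyl)amino group in place of hydrogen changed little. Going from phenyl down to methyl on the sulfur should therefore undo most of that modest rise, while the methyl on the nitrogen has no measured counterpart here. Compound 4 is expected to give about 5500 nM, within 2500 nM to 12000 nM, an expected step of a 2.5-fold lower number from compound 3 to compound 4 (0.41 log units; beyond the scatter).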

Compound 4, half-maximal inhibitory concentration: 2000 nM
The estimate for compound 4 lay 2.8-fold (0.44 log units) above the measured number, outside the stated range (below it).
By their numbers in this assay, from the lowest: compound 4; then compounds 1 and 2 (each within the scatter of the next); then compound 3.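

Until now, a sulfonyl-bearing group on this aromatic carbon had either changed little or raised the number in this assay, so hydrogen looked as good as anything tried there. Within the data shown here, the methyl(methylsulfonyl)amino group of compound 4 is the first to improve on hydrogen (a 2.1-fold lower number from compound 1 to compound 4 (0.32 log units; beyond the scatter)), and it also improves on the (propylsulfonyl)amino group (a 2.4-fold lower number from compound 2 to compound 4 (0.38 log units; beyond the scatter)) and, by the largest of these steps, on the (phenylsulfonyl)amino group (a 7.0-fold lower number from compound 3 to compound 4 (0.85 log units; beyond the scatter)). Nothing measured here explains why the number fell.

Compound 4 differs from compounds 2 and 3 both on the sulfur and on the nitrogen, so the compounds shown cannot tell how much of the gain comes from the methyl on the sulfur and how much from the methyl on the nitrogen; a methylsulfonylamino group that keeps its nitrogen hydrogen, or a propyl group on the sulfur with a methyl on the nitrogen, would separate the two. Also open, on these data alone, is how an amine or a carboxylic acid on this carbon would compare with hydrogen.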